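The source may report more compounds than this note shows. Statements on the series, on what has been measured and on what is new or still open speak of the compounds shown alone.

Within the data shown here, in a functional assay on HeLa cells (Homo sapiens) for antiproliferative activity, read by MTT assay, with a stated time of 72 h (on this read-out lower numbers stand for stronger inhibition and higher numbers for weaker inhibition), compound 3 `CCC/C=C/C(=O)Nc1cccc(Oc2nc(Nc3ccc(OC)cc3)nc3c2CSCC3)c1` gives 12800 nM, the lowest of the two true numbers so far, while compound 1 `CC(C)/C=C/C(=O)Nc1cccc(Oc2nc(Nc3ccn(C)n3)nc3c2CSCC3)c1` gives 40100 nM. Compound 2 `C/C=C/C(=O)Nc1cccc(Oc2nc(Nc3ccc(OC)cc3)nc3c2CSCC3)c1` reads > 50000 nM, which is a limit of the assay and not a number. Compound 4 `COc1ccc(Nc2nc3c(c(Oc4cccc(NC(=O)/C=C/C(C)C)c4)n2)CSCC3)cc1` has the same atoms as compound 3, joined differently: isopropyl in place of propyl on a double-bonded chain carbon bound to a double-bonded chain carbon. Among the measured compounds shown here, the one measured step on this chain, an at least 3.9-fold lower number from compound 2 to compound 3 (0.59 log units; beyond the scatter), added carbons, whereas this change adds none. Compound 1 also carries isopropyl but differs elsewhere too. No step beyond the scatter is therefore expected in this assay, and the estimated change is a 1.2-fold higher number from compound 3 to compound 4 (0.07 log units; within the scatter). For compound 4 the estimate is 15000 nM, with an expected range of 6000 nM to 40000 nM.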

Compound 4, half-maximal inhibitory concentration: 22900 nM
For compound 4 the middle estimate is 1.5-fold (0.18 log units) below the measured one; the measured number falls inside the stated range.
By their numbers in this assay, from the lowest: compounds 3, 4 and 1 (each within the scatter of the next, the first and the last beyond it). At a limit, above all of these: compound 2.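

In this assay, propyl and isopropyl at this position cannot be told apart, with a 1.8-fold higher number from compound 3 to compound 4 (0.25 log units; within the scatter), whereas replacing methyl with isopropyl counts, with an at least 2.1-fold lower number from compound 2 to compound 4 (0.33 log units; beyond the scatter), so a branched chain serves here as well as a straight one. Compound 2 gives a limit and not a number: the limit of > 50000 nM in this assay, at which 1 of the 4 values shown sits. With isopropyl in place, 4-methoxyphenyl and 1-methyl-1H-pyrazol-3-yl on a nitrogen on an aromatic ring also cannot be told apart, with a 1.8-fold lower number from compound 1 to compound 4 (0.24 log units; within the scatter).

As far as these compounds go, whether a longer chain such as hexyl, or a chain ending in an amine, would lower the number further remains open.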